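Sulfonyl aryl changes: from compound 3 to compound 4

The source may hold more compounds than are shown below. What is called first, only, known or untested is meant among the compounds shown, and "the series" means these compounds.

Measured compounds:
- compound 1 `CC(O)(CS(=O)(=O)c1ccc(S(F)(F)(F)(F)F)cc1)C(=O)Nc1ccc(S(F)(F)(F)(F)F)cc1` gives 28900 nM
- compound 2 `CC(O)(CS(=O)(=O)c1ccc(C(F)(F)F)cc1)C(=O)Nc1ccc(S(F)(F)(F)(F)F)cc1` gives 29300 nM
- compound 3 `CC(O)(CS(=O)(=O)c1cccc(C(F)(F)F)c1)C(=O)Nc1ccc(S(F)(F)(F)(F)F)cc1` gives 31900 nM

In a functional assay on DU-145 cells (Homo sapiens) for antiproliferative activity, read by propidium iodide staining, with a stated time of 96 h (on this read-out lower numbers stand for stronger inhibition and higher numbers for weaker inhibition), compound 3 gives 31900 nM and lies within the scatter of both compound 1 and compound 2, so the three values form a single group with no order among them.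

The next structure is compound 4 `CC(O)(CS(=O)(=O)c1ccc(OC(F)(F)F)cc1)C(=O)Nc1ccc(S(F)(F)(F)(F)F)cc1` with 4-(trifluoromethoxy)phenyl in place of 3-(trifluoromethyl)phenyl on a sulfonyl sulfur as the full change. The group on the sulfonyl sulfur is the only part that differs.

Among the measured compounds shown here, two measured steps bear on this change, since both alter that same group. The first is a 1.0-fold higher number from compound 1 to compound 2 (0.01 log units; within the scatter) and the second is a 1.1-fold higher number from compound 2 to compound 3 (0.04 log units; within the scatter) and neither goes beyond the scatter. For the measured compounds named here, no measured compound in this set carries 4-(trifluoromethoxy)phenyl, so the expectation is an extrapolation from these two steps alone.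

No step beyond the scatter is expected in this assay and the estimated step is a 1.1-fold lower number from compound 3 to compound 4 (0.03 log units; within the scatter) at its middle. For compound 4 the estimated value is 30000 nM with 17000 nM to 50000 nM as the expected range.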

Compound 4, half-maximal inhibitory concentration: 39300 nM
Compound 4: the middle estimate sits 1.3-fold (0.12 log units) below what was measured, and the stated range covers the measured number.
By their numbers in this assay, from the lowest: compounds 1, 2, 3 and 4 (each within the scatter of the next).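

In this assay, the fourth aryl group on the sulfonyl sulfur again gives no separation: 4-(trifluoromethoxy)phenyl in place of 3-(trifluoromethyl)phenyl gives a 1.2-fold higher number from compound 3 to compound 4 (0.09 log units; within the scatter), trifluoromethoxy in place of trifluoromethyl gives a 1.3-fold higher number from compound 2 to compound 4 (0.13 log units; within the scatter), and the same group in place of the five-fluorine, one-sulfur group gives a 1.4-fold higher number from compound 1 to compound 4 (0.13 log units; within the scatter). Among the compounds shown here, this is the first entering group with an oxygen and a hydrogen-bond acceptor, and with it all four compounds still fall within the scatter of one another, so the acceptor count of this group does not separate compound 4 from compound 3 on this read-out. No data bearing on the cause of these values accompany the series.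

From the compounds shown here alone, all four aryl groups on the sulfonyl sulfur carry a fluorinated substituent, so it stays open whether an amine or a carboxylic acid on that ring would give a step beyond the scatter. The rest of the structure is the same in all four compounds, which leaves open how this assay responds to a change on the amide side, such as replacing the pentafluorosulfanyl group with a nitrile.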